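Fluoro in Place of Nitro on the Sulfonyl Group

The compounds below may be only part of what the source reports. "The series", "measured", "known", "first", "only" and "open" are said of these compounds alone.

In a functional assay on SMMC-7721 cells (Homo sapiens) for cytotoxicity, read by MTT assay, with a stated time of 24 h (on this read-out lower numbers stand for stronger inhibition and higher numbers for weaker inhibition), compound 1 `CN1C/C(=C\c2cccnc2)C(=O)/C(=C/c2ccccc2C(F)(F)F)C1` gives 3900 nM and compound 2 `Cc1ccc(S(=O)(=O)N2C/C(=C\c3cccnc3)C(=O)/C(=C/c3ccccc3C(F)(F)F)C2)cc1` gives 6700 nM while compound 3 `O=C1/C(=C/c2cccnc2)CN(S(=O)(=O)c2ccc([N+](=O)[O-])cc2)C/C1=C\c1ccccc1C(F)(F)F` stands highest of the three at 15900 nM on that read-out. Compound 4 `O=C1/C(=C/c2cccnc2)CN(S(=O)(=O)c2ccc(F)cc2)C/C1=C\c1ccccc1C(F)(F)F` has fluoro in place of nitro on an aromatic carbon, with fluoro in place of nitro on an aromatic carbon as the full count of the change from compound 3. The nearest evidence is a 2.4-fold higher number from compound 2 to compound 3 (0.38 log units; beyond the scatter) for nitro in place of methyl, and a 4.1-fold higher number from compound 1 to compound 3 (0.61 log units; beyond the scatter) for (4-nitrophenyl)sulfonyl in place of methyl, both modest, while a 1.7-fold higher number from compound 1 to compound 2 (0.24 log units; within the scatter) stays within the scatter. Within the data shown here, no fluoro compound has been measured, so a modest step toward a lower number is expected, roughly the reverse of a 2.4-fold higher number from compound 2 to compound 3 (0.38 log units; beyond the scatter) in size. The expected step is a 2.1-fold lower number from compound 3 to compound 4 (0.33 log units; beyond the scatter) in these terms. Compound 4 is expected in this assay at 7500 nM with an estimated range from 3500 nM to 16000 nM as its bounds.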

Compound 4, half-maximal inhibitory concentration: 6390 nM
Compound 4: the middle estimate sits 1.2-fold (0.07 log units) above what was measured; low and high end bracket the measured number.
By their numbers in this assay, from the lowest: compounds 1, 4 and 2 (each within the scatter of the next); then compound 3.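

In this assay, replacing the nitro group at this aromatic carbon with fluoro gives a 2.5-fold lower number from compound 3 to compound 4 (0.40 log units; beyond the scatter), while fluoro in place of methyl gives a 1.0-fold lower number from compound 2 to compound 4 (0.02 log units; within the scatter), so of these three groups only nitro stands apart. (4-Fluorophenyl)sulfonyl in place of methyl on the amine nitrogen gives a 1.6-fold higher number from compound 1 to compound 4 (0.21 log units; within the scatter), so among the sulfonyl compounds only compound 3 lies beyond the scatter of compound 1. Nothing shown here explains why nitro differs. As far as these compounds go, how an amine or a methoxy group would read at this carbon remains open. So does whether these steps hold with other groups on the shared core.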